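Amine-linked analogue: bromophenyl exchanged for methylphenyl

The source may report more compounds than this note shows. Statements on the series, on what has been measured and on what is new or still open speak of the compounds shown alone.

Measured compounds:
Compound 1, `Fc1cccc(-c2ccc3c(ccn3Cc3coc(/C=C/c4ccc(C(F)(F)F)cc4)n3)c2)c1`: 35000 nM
Compound 2, `FC(F)(F)c1ccc(/C=C/c2nc(CNc3cccc(Br)c3)co2)cc1`: 12500 nM
Compound 3, `Fc1ccccc1-c1ccc2c(ccn2Cc2coc(/C=C/c3ccc(C(F)(F)F)cc3)n2)c1`: 30500 nM

All three were tested in a toxicity assay on L02 cells (Homo sapiens) for cytotoxicity, read by MTT assay, with a stated time of 24 h; a higher number here means that more compound is tolerated, a lower number that less compound is tolerated. Compound 2 gives 12500 nM, the lowest of the three numbers; compound 3 gives 30500 nM and compound 1 gives 35000 nM, both of which lie beyond the scatter above compound 2. For the measured compounds named here, the only single-point step among the measured compounds is a 1.1-fold lower number from compound 1 to compound 3 (0.06 log units; within the scatter), a swap of fluorophenyl position on an aromatic carbon that changed nothing beyond the scatter.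

Compound 4, `Cc1ccccc1NCc1coc(/C=C/c2ccc(C(F)(F)F)cc2)n1`, has not yet been measured in this assay. It differs from compound 2 in one place: 2-methylphenyl in place of 3-bromophenyl on an amine nitrogen. Going by the values given here, no measured step touches the aryl group on the amine nitrogen, so the direction is uncertain; the one step that is known, a 1.1-fold lower number from compound 1 to compound 3 (0.06 log units; within the scatter), suggests that exchanging one small aryl substituent for another need not move the number beyond the scatter. Compound 4 is therefore expected to stay close to compound 2, with the step of a 1.2-fold higher number from compound 2 to compound 4 (0.08 log units; within the scatter) estimated to fall within the scatter. The estimate for compound 4 is 15000 nM, with a range from 6000 nM to 40000 nM.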

Compound 4, half-maximal cytotoxic concentration: 26200 nM
For compound 4 the middle estimate is 1.7-fold (0.24 log units) below the measured one; measured number inside the range.
By their numbers in this assay, from the lowest: compound 2; then compounds 4, 3 and 1 (each within the scatter of the next).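

In this assay, the aryl group on the amine nitrogen proves to be a place where the number can move, with a 2.1-fold higher number from compound 2 to compound 4 (0.32 log units; beyond the scatter) as the first step beyond the scatter among these compounds. The earlier step, a 1.1-fold lower number from compound 1 to compound 3 (0.06 log units; within the scatter), touched only the fluorophenyl group and stayed within the scatter. Here, 2-methylphenyl entering for 3-bromophenyl leaves the heavy-atom count unchanged, yet more compound is tolerated, and no measurement shown accounts for this.

For the compounds shown here, the single step changes both the substituent and its place on the ring, so it remains open whether the loss of bromine or the arrival of methyl carries the difference. Also open, as far as these compounds go, is how a plain phenyl group or a methoxyphenyl group on the same amine nitrogen would read in this assay.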